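Compound 1 and a tert-butyl for trifluoromethyl exchange

A few compounds are considered here, and "the series" means these few. Any claim that something is new, unique, unknown or untested is made for them only; others in the source may bear on it.

Compound 1 `O=C(c1ccc(-c2nc(-c3ccc(C(F)(F)F)cc3)no2)s1)C(F)(F)F` was examined in an assay for inhibition of histone deacetylase 4 (Homo sapiens) (on this read-out lower numbers stand for stronger inhibition and higher numbers for weaker inhibition), where compound 1 gives 200 nM. Among the three compounds measured so far it holds the second highest number. Nearest to it is compound 2 `O=C(c1ccc(-c2ncc(-c3ccccc3)s2)s1)C(F)(F)F`, which in this assay gives 1500 nM, a gap beyond the usual scatter. Furthest from it is compound 3 `O=C(c1ccc(-c2nc(Cc3cccs3)no2)s1)C(F)(F)F`, which in this assay gives 15 nM, likewise beyond the scatter. Within the data shown here, no two of these measured compounds differ in a single place, so no measured single step is available to draw upon.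

Compound 4 `CC(C)(C)c1ccc(-c2noc(-c3ccc(C(=O)C(F)(F)F)s3)n2)cc1` is the next compound to be measured. Set against compound 1, compound 4 shows one change: tert-butyl in place of trifluoromethyl on an aromatic carbon. The group that leaves and the group that enters are both placed on an aromatic carbon of a six-membered aromatic ring of carbon only, para to a large group. Among the measured compounds shown here, with no measured step of this kind to lean on, the expectation for this assay is a step from compound 1 to compound 4 of a 1.3-fold higher number from compound 1 to compound 4 (0.10 log units; within the scatter), within the scatter or only slightly beyond it. Compound 4 is therefore estimated to give 250 nM in this assay, with a range from 80 nM to 800 nM.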

Compound 4, half-maximal inhibitory concentration: > 2000 nM
Compound 4: no number, only a limit; the forecaster's own chance of this, stated with the estimate: 5%; middle value at least 8.0-fold (0.90 log units) from the limit.
By their numbers in this assay, from the lowest: compound 3; then compound 1; then compound 2. At a limit, above all of these: compound 4.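

In this assay, among these compounds, tert-butyl in place of trifluoromethyl on an aromatic carbon gives an at least 10-fold higher number from compound 1 to compound 4 (1.00 log units; beyond the scatter), the first measured single change in this set, and it shows that this position is sensitive to the exchange even though the two groups have the same number of heavy atoms. For compound 4, the value > 2000 nM is a limit of the assay and not a number. The step therefore fixes only the least size of the loss, not its full size: the limit of > 2000 nM in this assay, at which 1 of the 4 values shown sits.

Going by these compounds, how far compound 4 lies past that limit stays open, as does whether the same exchange would have a similar effect on a different core. On these data alone, what a smaller group such as methyl, or an amine or a methoxy group, would give at this position also remains unknown.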